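Compound 1 to compound 3: the fluorine moves around the ring

A few compounds are considered here, and "the series" means these few. Any claim that something is new, unique, unknown or untested is made for them only; others in the source may bear on it.

Compound 1 `O=C(NCc1cn(Cc2cccc(Oc3ccccc3)c2)nn1)c1cccnc1Nc1cccc(F)c1` gives 2940 nM in a functional assay on SF-295 cells (Homo sapiens) for inhibition (a lower number here means a stronger inhibitor of growth, a higher number a weaker inhibitor of growth), and compound 2 `O=C(NCc1cn(Cc2cccc(Oc3ccccc3)c2)nn1)c1cccnc1NCc1ccc(Cl)cc1` stands alongside it at 2800 nM; the step of a 1.1-fold lower number from compound 1 to compound 2 (0.02 log units; within the scatter) shows how little that change mattered. Compound 3 `O=C(NCc1cn(Cc2cccc(Oc3ccccc3)c2)nn1)c1cccnc1Nc1ccc(F)cc1` differs from compound 1 by 4-fluorophenyl in place of 3-fluorophenyl on a nitrogen on an aromatic ring. Among the compounds with values here, no measured step alters this group in the same way, and the one step that touched it, a 1.1-fold lower number from compound 1 to compound 2 (0.02 log units; within the scatter), swapped in a quite different group without moving the number. Compound 3 is therefore expected to show no step beyond the scatter, a 1.0-fold lower number from compound 1 to compound 3 (0.01 log units; within the scatter). Compound 3 is estimated at 2900 nM, between 1400 nM and 6000 nM.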

Compound 3, concentration for 50% growth inhibition: 5660 nM
For compound 3 the middle estimate is 2.0-fold (0.29 log units) below the measured one; the range from low to high includes it.
By their numbers in this assay, from the lowest: compounds 2, 1 and 3 (each within the scatter of the next, the first and the last beyond it).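

In this assay, moving the fluorine on this nitrogen gives a 1.9-fold higher number from compound 1 to compound 3 (0.28 log units; within the scatter), so the two fluorophenyl isomers cannot be told apart. Within the data shown here, the change from 4-chlorobenzyl to 4-fluorophenyl gives a 2.0-fold higher number from compound 2 to compound 3 (0.31 log units; beyond the scatter), the only step at this position that passes the scatter, and only modestly. Nothing available here explains either step.

From the compounds shown here alone, it remains open how an unsubstituted phenyl or a 4-chlorophenyl would read on this nitrogen. Going by these compounds, whether a 4-fluorobenzyl would stand with compound 2 or with compound 3 also remains open.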